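The compounds below may be only part of what the source reports. "The series", "measured", "known", "first", "only" and "open" are said of these compounds alone.

In a functional assay on NUGC-3 cells (Homo sapiens) for antiproliferative activity, read by sulforhodamine B assay (on this read-out lower numbers stand for stronger inhibition of growth and higher numbers for weaker inhibition of growth), compound 1 `CC(C)CCCOc1cccc(O)c1C(=O)/C=C/c1ccc(O)cc1` gives 3520 nM. Compound 3 `CC(C)(C)CCOc1cccc(O)c1C(=O)/C=C/c1ccc(C(=O)O)cc1` gives 5440 nM, and this number lies within the usual scatter of the value for compound 1, so the two cannot be ranked. Compound 2 `COc1cccc(OCCC(C)(C)C)c1C(=O)/C=C/c1ccc(O)cc1` is reported only as a limit, > 30000 nM. Compound 1 therefore stands as one of just two compounds with an exact number, and that number is matched, within scatter, by compound 3.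

The next compound to consider is compound 4 `CCCCCCOc1cccc(O)c1C(=O)/C=C/c1ccc(O)cc1`. It has the same atoms as compound 1, joined differently: propyl in place of isopropyl on a saturated chain carbon, three bonds along the chain from an oxygen on an aromatic ring. In words, propyl takes the place of isopropyl on a saturated chain carbon, three bonds along the chain from an oxygen on an aromatic ring. Cut one bond further out, the same difference reads 4-methylpentyl to hexyl.

For the measured compounds named here, no two measured compounds differ in one place only, so the data give no direct measure of what such a change does. The expectation is therefore no step beyond the scatter, in either direction, starting from compound 1 at 3520 nM. The estimated change, a 1.1-fold higher number from compound 1 to compound 4 (0.06 log units; within the scatter), stays within that scatter. Compound 4 is expected at 4000 nM, with an estimated range from 1700 nM to 9500 nM.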

Compound 4, concentration for 50% growth inhibition: > 30000 nM
Compound 4 was reported as a limit; the forecaster's own chance of this, stated with the estimate: 5%; middle value at least 7.5-fold (0.87 log units) away from the limit.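

Swapping isopropyl for propyl, on a saturated chain carbon three bonds along the chain from an oxygen on an aromatic ring, leaves the atoms unchanged yet gives an at least 8.5-fold higher number from compound 1 to compound 4 (0.93 log units; beyond the scatter) in this assay. For the compounds shown here, this is the first pair in the set that differs in one place only, so it shows what the earlier compounds could not: at this position, how the same atoms are joined at the end of the chain is enough to separate a measurable number, with 4-methylpentyl in compound 1, from no exact number, with hexyl in compound 4. Compound 4 is reported as > 30000 nM, which is a limit, so the step gives only a minimum and its true size stays unknown: the limit of > 30000 nM in this assay, at which 2 of the 4 values shown sit.

This single pair does not tell why the straight chain fares so differently from the branched one, or whether the isopropyl ending would keep its advantage on a shorter or longer chain. Going by these compounds, what a chain ending in an amine or a cyclopentyl ring would do at this place also remains open.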